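This account rests on a few compounds, and the source may have more. Where it says the series, first, only, none or still open, it means among the compounds named here.

Compound 1 `C[C@@H]1CC(c2cnc3c(C#N)nn([C@H](C)c4ccc(Cl)cc4Cl)c3n2)=CC[C@@H]1N1CCC[C@H]1C(C)(C)O` was tested in an assay on CCRF-CEM cells for antagonist activity at C-C chemokine receptor type 4 (Homo sapiens), read by CellTiter-Glo, with stated times of 30 min and 60 min, in the presence of a further agent that is not named here (on this read-out lower numbers stand for stronger inhibition and higher numbers for weaker inhibition), and gave 1200 nM. Compound 2 `Cc1nn([C@H](C)c2ccc(Cl)cc2Cl)c2nc(N3CC[C@H](N4CCC[C@H]4CCC(N)=O)[C@H](C)C3)cnc12` gave 355 nM in this assay. Of these two numbers, compound 1 stands highest; compound 2 gives the lower number, and the gap between them lies beyond the usual scatter. Within the data shown here, the two compounds differ in more than one place, so no single step connects them, and only their two values can be compared.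

Compound 3 `C[C@@H]1CC(c2cnc3c(C#N)nn([C@H](C)c4ccc(Cl)cc4Cl)c3n2)=CC[C@@H]1N1CCC[C@H]1C` is an analogue of compound 1 that has not yet been measured. methyl in place of 1-hydroxy-1-methylethyl on a saturated ring carbon The change removes the hydrogen-bond donor and the hydrogen-bond acceptor counted for the leaving group and otherwise leaves compound 1 unchanged. Among the measured compounds shown here, no measured pair shows this change, so its effect on the read-out is open. In this assay the step of a 1.4-fold higher number from compound 1 to compound 3 (0.15 log units; within the scatter) is expected to be small, most likely toward a somewhat higher number, and may not go beyond the scatter. Compound 3 is therefore estimated at 1700 nM, with a likely range from 600 nM to 5000 nM.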

Compound 3, half-maximal inhibitory concentration: 44 nM
Compound 3: the middle estimate sits 39-fold (1.59 log units) above what was measured, outside the stated range (below it).
By their numbers in this assay, from the lowest: compound 3; then compound 2; then compound 1.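

In this assay the exchange of 1-hydroxy-1-methylethyl for methyl on this saturated ring carbon, next to the ring nitrogen, gives a 27-fold lower number from compound 1 to compound 3 (1.44 log units; beyond the scatter) and is a large step. The first two compounds differed in more than one place and could not isolate any single position, whereas this pair shows that the group at this one carbon can by itself move the number well beyond the scatter, with everything else in compound 1 unchanged. The smaller group, with no hydrogen-bond donor or acceptor, goes with the much lower number here, but nothing given here explains why the number falls.

As far as these compounds go, a single step does not separate the loss of the hydroxy group from the loss of the two extra methyl-sized carbons, so it remains open how groups such as hydroxymethyl, ethyl or methoxymethyl would read at this carbon. From the compounds shown here alone, it is also open whether the same exchange would have a similar effect on the core of compound 2, or whether an amine at this carbon would keep the lower number.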